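Aryl swap on the oxazole arm of a benzothiazole series

A few compounds are considered here, and "the series" means these few. Any claim that something is new, unique, unknown or untested is made for them only; others in the source may bear on it.

Measured so far:
- Compound 1 `COc1ccc(-c2cc(CN(c3nc4ccc(F)cc4s3)c3nc4ccc(OC)cc4s3)on2)cc1`: 38800 nM
- Compound 2 `COc1ccc2nc(N(Cc3cc(-c4cc(OC)c(OC)c(OC)c4)no3)c3nc4ccc(F)cc4s3)sc2c1`: 61900 nM

In a functional assay on A549 cells (Homo sapiens) for antiproliferative activity, read by MTT assay (a higher number here means a weaker inhibitor, a lower number a stronger inhibitor), compound 2 stands highest of the two numbers, though the step between them is a 1.6-fold higher number from compound 1 to compound 2 (0.20 log units; within the scatter) and so within the scatter. Compound 3 `COc1ccc2nc(N(Cc3cc(-c4ccccc4F)no3)c3nc4ccc(F)cc4s3)sc2c1` is unmeasured; it differs from compound 2 by 2-fluorophenyl in place of 3,4,5-trimethoxyphenyl on an aromatic carbon. Going by the values given here, the only step that bears on this change is the aryl exchange from compound 1 to compound 2, which stayed within the scatter. No step beyond the scatter is therefore expected for compound 3, with the shift a 1.4-fold lower number from compound 2 to compound 3 (0.14 log units; within the scatter) taken as noise. Compound 3 is estimated at 45000 nM, with a range from 15000 nM to 150000 nM.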

Compound 3, half-maximal inhibitory concentration: 51800 nM
The estimate for compound 3 lay 1.2-fold (0.06 log units) below the measured number, and the stated range covers the measured number.
By their numbers in this assay, from the lowest: compounds 1, 3 and 2 (each within the scatter of the next).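

In this assay, 2-fluorophenyl on the aromatic carbon next to the ring nitrogen gives a 1.2-fold lower number from compound 2 to compound 3 (0.08 log units; within the scatter) and a 1.3-fold higher number from compound 1 to compound 3 (0.13 log units; within the scatter), so all three aryl groups at this position now sit within the scatter of each other. Even the exchange of 3,4,5-trimethoxyphenyl, with 3 hydrogen-bond acceptors, for 2-fluorophenyl, with 0, produces no step beyond the scatter. No supporting data bear on why this position tolerates these exchanges.

Still open, on these data alone, is whether a non-aryl group here, such as an amine or a carboxylic acid, would shift the number beyond the scatter. Also open, as far as these compounds go, is whether changes elsewhere on the shared core would do so.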